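The source may hold more compounds than are shown below. What is called first, only, known or untested is meant among the compounds shown, and "the series" means these compounds.

Measured so far in a functional assay on NCI-H1975 cells (Homo sapiens) for inhibition, read by MTT assay, with a stated time of 72 h; a lower number here means a stronger inhibitor, a higher number a weaker inhibitor:
compound 1 `C=CC(=O)Nc1cccc(NC(=O)CSc2nc(Nc3ccccc3C)c3ccccc3n2)c1` — 9920 nM
compound 2 `C=CC(=O)Nc1cccc(NC(=O)CSc2nc(Nc3cccc(Cl)c3)c3ccccc3n2)c1` — 9460 nM

Compound 2 carries the lower of the two numbers, but the step of a 1.0-fold lower number from compound 1 to compound 2 (0.02 log units; within the scatter) sits inside the scatter, so the two compounds are not separated. Compound 3 `C=CC(=O)Nc1cccc(NC(=O)CSc2nc(Nc3cccc([N+](=O)[O-])c3)c3ccccc3n2)c1` differs from compound 2 by nitro in place of chloro on an aromatic carbon. Within the data shown here, the only step that bears on a change at this position is the one from compound 1 to compound 2, and it was flat. No reason is therefore seen for a shift beyond the scatter, and compound 3 is expected to give about 9500 nM (range 4000 nM to 25000 nM), a step of a 1.0-fold higher number from compound 2 to compound 3 (0.00 log units; within the scatter).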

Compound 3, half-maximal inhibitory concentration: 22600 nM
Compound 3: the middle estimate sits 2.4-fold (0.38 log units) below what was measured, within the range that was stated.
By their numbers in this assay, from the lowest: compounds 2 and 1 (each within the scatter of the next); then compound 3.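

Nitro in place of chloro moves the number in this assay with a 2.4-fold higher number from compound 2 to compound 3 (0.38 log units; beyond the scatter) and 3-nitrophenyl in place of 2-methylphenyl gives a 2.3-fold higher number from compound 1 to compound 3 (0.36 log units; beyond the scatter) so that compound 3 is the weakest of the three, though both steps are modest. The earlier flat step therefore does not extend to every group on this ring. Nothing at hand accounts for the shift. Going by these compounds, whether an amine or a carboxylic acid in place of nitro would move the number further stays open, as does whether the gap between chloro and nitro holds at other places on the ring.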